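The source may hold more compounds than are shown below. What is called first, only, known or untested is meant among the compounds shown, and "the series" means these compounds.

Compound 1 `Cc1nc(N)c2c(-c3ccco3)cn([C@@H]3O[C@H](CO)[C@@H](O)[C@H]3O)c2n1` — in a functional assay on A549 cells (Homo sapiens), read by MTT assay, with a stated time of 72 h (a higher number here means a weaker inhibitor, a lower number a stronger inhibitor), compound 1 gives > 20000 nM, which is a limit of the assay and not a number.
Compound 2 `Cc1nc(N)c2c(-c3cc4ccccc4o3)cn([C@@H]3O[C@H](CO)[C@@H](O)[C@H]3O)c2n1` — in this assay compound 2 gives > 20000 nM, again a limit rather than a number.
Compound 3 `CNc1ncnc2c1c(-c1cc3ccccc3o1)cn2[C@@H]1O[C@H](CO)[C@@H](O)[C@H]1O` — in this assay compound 3 gives > 20000 nM, also a limit.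

All three measured compounds sit at the same limit, a point summed up in the limit of > 20000 nM in this assay, at which 3 of the 3 values shown sit. From compound 2 to compound 1 the change is furan-2-yl in place of 1-benzofuran-2-yl on an aromatic carbon, and the step that the two limits leave unreadable from compound 2 to compound 1 cannot be read, since both ends are limits. Compound 3 carries a different core from compound 2; the difference between the two cores is not broken down here.

Compound 4 `CNc1ncnc2c1c(-c1ccco1)cn2[C@@H]1O[C@H](CO)[C@@H](O)[C@H]1O` has not yet been measured in this assay. It stands to compound 3 as compound 1 stands to compound 2: the change is furan-2-yl in place of 1-benzofuran-2-yl on an aromatic carbon, the same change at the same place. Since compound 3 gives only a limit, > 20000 nM, and the parallel pair gave no readable step, compound 4 is expected to remain at the limit as well. The expected step that the limit leaves unreadable from compound 3 to compound 4 is therefore estimated as essentially none, and compound 4 is estimated at 30000 nM, within 15000 nM to 80000 nM.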

Compound 4, half-maximal inhibitory concentration: 2570 nM
For compound 4 the middle estimate is 12-fold (1.07 log units) above the measured one, and the stated range ends above it.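

In this assay, furan-2-yl in place of 1-benzofuran-2-yl on the core of compound 3 gives an at least 7.7-fold lower number from compound 3 to compound 4 (0.89 log units; beyond the scatter), so on this core the smaller group brings a readable number where the larger one left only a limit. The same change on the core of compound 1 cannot be read, since compound 1 and compound 2 both stand at a limit; the series therefore does not show that the gain carries over to that core, nor that it fails to. The transfer rests on one readable step, and the remaining values give no size for comparison: the limit of > 20000 nM in this assay, at which 3 of the 4 values shown sit.

Only furan-2-yl and 1-benzofuran-2-yl are shown on this aromatic carbon, so it remains open how an amine or a carboxylic acid there would behave on the core of compound 4. From the compounds shown here alone, it also remains open whether any group at this place would give a readable number on the core of compound 1.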